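A Second Chloro on Compound 3

The source may report more compounds than this note shows. Statements on the series, on what has been measured and on what is new or still open speak of the compounds shown alone.

Measured in a functional assay on MCF7 cells (Homo sapiens) for antiproliferative activity, read by MTT assay, with a stated time of 48 h (a higher number here means a weaker inhibitor, a lower number a stronger inhibitor), are these values:
Compound 1 `Clc1cc2nc(-c3cn(-c4ccccc4)nc3-c3ccccc3)[nH]c2cc1Cl` gives 7560 nM
Compound 2 `Fc1ccc(-c2nn(-c3ccccc3)cc2-c2nc3cc(Cl)c(Cl)cc3[nH]2)cc1` gives 6930 nM
Compound 3 `Clc1ccc(-c2nn(-c3ccccc3)cc2-c2nc3cc(Cl)ccc3[nH]2)cc1` gives 1170 nM

Compound 3 has the lowest number of the three, and its gaps to compound 1 and compound 2 lie beyond the scatter. Going to compound 4 `Clc1ccc(-c2nn(-c3ccccc3)cc2-c2nc3cc(Cl)c(Cl)cc3[nH]2)cc1` puts chloro in place of hydrogen on an aromatic carbon and nothing else changes. Among the compounds with values here, the one measured single-place step, fluoro in place of hydrogen, is a 1.1-fold lower number from compound 1 to compound 2 (0.04 log units; within the scatter) and it is a different swap, so it guides only weakly. Compound 1 and compound 2 already carry the added chloro, and both hold higher numbers than compound 3 while also differing from it elsewhere. A moderately higher number in this assay is therefore expected. The expected step is a 3.0-fold higher number from compound 3 to compound 4 (0.48 log units; beyond the scatter) as an estimate only. Compound 4 is estimated at 3500 nM with an expected range from 1100 nM to 9000 nM as its likely span.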

Compound 4, half-maximal inhibitory concentration: 48300 nM
For compound 4 the middle estimate is 14-fold (1.14 log units) below the measured one; the whole stated range lies below it.
By their numbers in this assay, from the lowest: compound 3; then compounds 2 and 1 (each within the scatter of the next); then compound 4.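

In this assay, adding a chloro ortho to a chloro group on the fused system gives the largest step here, a 41-fold higher number from compound 3 to compound 4 (1.62 log units; beyond the scatter), so a single added atom at this position can greatly weaken activity. Elsewhere in the molecule, the change is smaller but still beyond the scatter: chloro in place of hydrogen gives a 6.4-fold higher number from compound 1 to compound 4 (0.81 log units; beyond the scatter), and chloro in place of fluoro gives a 7.0-fold higher number from compound 2 to compound 4 (0.84 log units; beyond the scatter). No measurement here explains the size of these steps. On these data alone, whether a methyl or an amine on that aromatic carbon would weaken activity as much remains open.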